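The source may report more compounds than this note shows. Statements on the series, on what has been measured and on what is new or still open speak of the compounds shown alone.

- compound 1 `Cc1cc(=O)c2c(O)cc(O)c([C@H]3CCN(C)C[C@H]3OC(=O)c3ccco3)c2o1`: 13%
- compound 2 `CCOC(=O)N1CCN(Cc2c(O)c([C@H]3CCN(C)C[C@H]3O)c3oc(C)cc(=O)c3c2O)CC1`: 4%
- compound 3 `Cc1oc2c([C@H]3CCN(C)C[C@H]3O)c(O)cc(O)c2c(=O)c1C(O)c1ccc(Cl)cc1`: 15%

These three compounds were tested in a functional assay on MIA PaCa-2 cells (Homo sapiens) for inhibition, read by MTT assay, with a stated time of 48 h, tested at 10 uM; a lower number here means less inhibition of growth, a higher number more inhibition of growth at the concentration tested. Compound 3, at 15%, lies within the usual scatter of compound 1, at 13%, so these two values cannot be told apart. Compound 2, at 4%, lies lower than compound 3, and that gap is beyond the scatter.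

The next compound to consider is compound 4 `Cc1oc2c([C@H]3CCN(C)C[C@H]3O)c(O)cc(O)c2c(=O)c1C(O)c1ccc(F)c(Br)c1`. It keeps everything in compound 3 except for one group, with 3-bromo-4-fluorophenyl in place of 4-chlorophenyl on a saturated chain carbon bound to an aromatic carbon and an oxygen on a saturated carbon. Both groups contain one six-membered aromatic ring of carbon only.

Within the data shown here, no two measured compounds differ in just one place, so the data give no direct measure of what such a swap does. The best starting point is therefore compound 3 itself, at 15%. The estimated change is a number 2 percentage points higher from compound 3 to compound 4 (within the scatter), and no shift beyond the scatter is expected in either direction. For compound 4 the expected value in this assay is 17%, within an estimated range from 5% to 34%.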

Compound 4, percent growth inhibition at one concentration: 9%
For compound 4 the middle estimate is 8 percentage points above the measured one; measured number inside the range.
By their numbers in this assay, from the lowest: compounds 2, 4, 1 and 3 (each within the scatter of the next, the first and the last beyond it).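

Among these compounds, compounds 3 and 4 form the first pair that differs in only one place, so they give the first direct reading of a change on the saturated chain carbon bound to an aromatic carbon and an oxygen on a saturated carbon. In this assay, putting 3-bromo-4-fluorophenyl in place of 4-chlorophenyl gives a number 6 percentage points lower from compound 3 to compound 4 (within the scatter), so at this position the two phenyl groups, with 7 and 8 heavy atoms, cannot be told apart at the concentration tested. No measurement is available that would explain this result or link it to any property of the groups.

The swap removes chlorine and brings in bromine and fluorine together, so this pair cannot show what each halogen contributes on its own. It also leaves open what happens when the phenyl ring itself is replaced at this position, for example by an amine, a carboxylic acid or a longer carbon chain, and whether any such group would move the growth inhibition beyond the usual scatter.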